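The compounds below may be only part of what the source reports. "The series", "measured", "known", "first", "only" and "open" are said of these compounds alone.

Compound 1 `N#CC1=C(N)Oc2c(c3nc4ccccc4nc3c3ccccc23)C12C(=O)N(Cc1cnnn1-c1ccc([N+](=O)[O-])cc1)c1ccccc12` and compound 2 `Cc1ccc(C)c(-n2nncc2CN2C(=O)C3(C(C#N)=C(N)Oc4c3c3nc5ccccc5nc3c3ccccc43)c3ccccc32)c1` share one core and differ only in the group on the aromatic nitrogen. In a functional assay on MCF7 cells (Homo sapiens) for antiproliferative activity, read by MTT assay, with a stated time of 48 h (a higher number here means a weaker inhibitor, a lower number a stronger inhibitor), compound 1 reaches only the assay limit > 50000 nM. In this assay compound 2 likewise reaches only the assay limit > 50000 nM. The step that the two limits leave unreadable from compound 1 to compound 2 therefore cannot be read, since both values sit at the limit of > 50000 nM in this assay, at which 2 of the 2 values shown sit. Compound 3 `N#CC1=C(N)Oc2c(c3nc4ccccc4nc3c3ccccc23)C12C(=O)N(Cc1cnnn1-c1ccc(F)c(Cl)c1)c1ccccc12` carries the change (3-chloro-4-fluorophenyl in place of 2,5-dimethylphenyl on an aromatic nitrogen). Going by the values given here, the only measured step that bears on it, from compound 1 to compound 2, is unreadable; no measured step gives a size for any change on this aromatic nitrogen. Compound 2 stands at the limit, and nothing shown separates it from compound 1. The expected step is a number no higher from compound 2 to compound 3 (the limit leaves the size open), of no readable size, with a further limit the likeliest outcome. The estimate for compound 3 in this assay is 50000 nM, expected to lie between 20000 nM and 200000 nM.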

Compound 3, half-maximal inhibitory concentration: > 50000 nM
Compound 3: only a limit was reported (the forecaster's own chance of this, stated with the estimate: 75%); the middle value lies on the limit itself.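

No new step can be read among compound 1, compound 2 and compound 3 in this assay, since each value is only a limit and none gives a number: the limit of > 50000 nM in this assay, at which 3 of the 3 values shown sit.
The compounds shown leave open whether any group on the aromatic nitrogen would give a measurable value, and how large any such change would be.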